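Methoxycarbonyl in place of cyano on the measured series

A few compounds are considered here, and "the series" means these few. Any claim that something is new, unique, unknown or untested is made for them only; others in the source may bear on it.

compound 1 `FC(F)(F)c1ccc(Nc2ncnc3sc(Nc4c(Cl)cccc4Cl)nc23)cc1`: 12 nM
compound 2 `N#Cc1cc(Cl)c(Nc2nc3c(Nc4ccc(C(F)(F)F)cc4)ncnc3s2)c(Cl)c1`: 95 nM

Among the compounds with values here, in a functional assay on HEK293 cells for antagonist activity at transient receptor potential cation channel subfamily V member 1 (Homo sapiens), read by calcium flux (on this read-out lower numbers stand for stronger inhibition and higher numbers for weaker inhibition), compound 2 gives the higher of the two numbers; its nearest neighbour is compound 1, and the single measured step, a 7.9-fold higher number from compound 1 to compound 2 (0.90 log units; beyond the scatter), lies beyond the scatter. Compound 3 `COC(=O)c1cc(Cl)c(Nc2nc3c(Nc4ccc(C(F)(F)F)cc4)ncnc3s2)c(Cl)c1` differs from compound 2 by methoxycarbonyl in place of cyano on an aromatic carbon. Within the data shown here, only that one step touches this site, and it swaps hydrogen for cyano, not cyano for an ester, so it bears on the change only loosely. Compound 3 is therefore expected to stay near compound 2, with a step of a 1.6-fold higher number from compound 2 to compound 3 (0.20 log units; within the scatter), and an estimated 150 nM in this assay, ranging from 40 nM to 600 nM.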

Compound 3, half-maximal inhibitory concentration: 820 nM
For compound 3 the middle estimate is 5.5-fold (0.74 log units) below the measured one, and the stated range ends below it.
By their numbers in this assay, from the lowest: compound 1; then compound 2; then compound 3.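

At this position in this assay, methoxycarbonyl is no stand-in for the nitrile: the swap gives an 8.6-fold higher number from compound 2 to compound 3 (0.94 log units; beyond the scatter) and so moves the number again in the direction seen on going from hydrogen to cyano. Against hydrogen at the same carbon, methoxycarbonyl gives a 68-fold higher number from compound 1 to compound 3 (1.83 log units; beyond the scatter) and the order across these compounds runs hydrogen, cyano, methoxycarbonyl. Nothing available here accounts for this order.

Open, from the compounds shown here alone, is how a carboxylic acid or a primary amide at this carbon would fall in that order. Also open, going by these compounds, is whether methyl or fluoro would stay closer to compound 1.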